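Ethoxycarbonyl in Place of Chloro on the Amide Aryl Ring

A few compounds are considered here, and "the series" means these few. Any claim that something is new, unique, unknown or untested is made for them only; others in the source may bear on it.

Of the compounds shown here, three sharing one core have been measured in a functional assay on SK-OV-3 cells (Homo sapiens) for antiproliferative activity, read by MTT assay, with a stated time of 72 h; a higher number here means a weaker inhibitor, a lower number a stronger inhibitor. Compound 1 `CCNC(=O)CCc1cccc2c1B(O)OC2` gives > 100000 nM, a limit of the assay rather than a number. Compound 2 `O=C(CCc1cccc2c1B(O)OC2)NCc1ccccc1` likewise gives > 100000 nM, again a limit. For the measured compounds named here, compound 3 `O=C(CCc1cccc2c1B(O)OC2)Nc1ccc(Cl)cc1` gives 5000 nM, the only number in this assay; the steps of an at least 20-fold lower number from compound 1 to compound 3 (1.30 log units; beyond the scatter) and an at least 20-fold lower number from compound 2 to compound 3 (1.30 log units; beyond the scatter) are both large, while the step that the two limits leave unreadable from compound 1 to compound 2 cannot be read between two limits.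

Compound 4 `CCOC(=O)c1ccc(NC(=O)CCc2cccc3c2B(O)OC3)cc1` differs from compound 3 in one place: ethoxycarbonyl in place of chloro on an aromatic carbon. Going by the values given here, no measured step touches this position, since every step so far exchanges the whole group on the amide nitrogen, and the two limits give no further guidance. Compound 4 is therefore expected to stay close to compound 3, with a step of no change at the digits printed from compound 3 to compound 4 (within the scatter), within the scatter. The estimate for compound 4 in this assay is 5000 nM, between 1500 nM and 20000 nM.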

Compound 4, half-maximal inhibitory concentration: > 100000 nM
Compound 4 gave a limit, no number (the forecaster's own chance of this, stated with the estimate: 15%); at least 20-fold (1.30 log units) between middle value and limit.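

The aromatic carbon that carries chloro matters in this assay: ethoxycarbonyl in place of chloro gives an at least 20-fold higher number from compound 3 to compound 4 (1.30 log units; beyond the scatter). The earlier steps shown here exchanged the whole group on the amide nitrogen, whereas this one shows that a single change on the aryl ring, with that ring kept, is enough to lose the measurable value. Compound 4 gives > 100000 nM, a limit of the assay and not a number, so the full size of the step stays unknown, and compound 3 alone keeps a number in this set: the limit of > 100000 nM in this assay, at which 3 of the 4 values shown sit.

Only chloro and ethoxycarbonyl are shown on this carbon, so it remains open how a fluoro, a methoxy, an amine or a carboxylic acid would read there. As far as these compounds go, it is also open what an unsubstituted phenyl on the amide nitrogen would give, which would show whether chloro itself matters for the value of compound 3.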